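Adding a nitro group to compound 2

This account rests on a few compounds, and the source may have more. Where it says the series, first, only, none or still open, it means among the compounds named here.

In a functional assay on HCT-116 cells (Homo sapiens) for inhibition, with a stated time of 72 h (on this read-out higher numbers stand for weaker inhibition and lower numbers for stronger inhibition), compound 1 (`CNC(=O)C1=C[C@@H]2[C@@H](C(C)C)CC[C@@]3(CO3)[C@H]2C(=O)OC1`) gives 7100 nM and compound 2 (`CC(C)[C@H]1CC[C@@]2(CO2)[C@H]2C(=O)OCC(C(=O)OCc3ccc(-c4ccccc4)o3)=C[C@H]12`) gives 220 nM as the lower, stronger of the two numbers. Compound 3 (`CC(C)[C@H]1CC[C@@]2(CO2)[C@H]2C(=O)OCC(C(=O)OCc3ccc(-c4ccc([N+](=O)[O-])cc4)o3)=C[C@H]12`) differs from compound 2 in one place (nitro in place of hydrogen on an aromatic carbon): nitro in place of hydrogen on an aromatic carbon, para to a large group, so phenyl becomes 4-nitrophenyl. For the measured compounds named here, no measured pair shows this change, so no shift beyond the usual scatter is expected, and the estimated 1.1-fold lower number from compound 2 to compound 3 (0.04 log units; within the scatter) has no firm direction. The estimate puts compound 3 at 200 nM (range 70 nM to 600 nM).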

Compound 3, half-maximal inhibitory concentration: 620 nM
Compound 3: middle estimate off by 3.1-fold (0.49 log units), on the low side; the measured number lies above the stated range.
By their numbers in this assay, from the lowest: compound 2; then compound 3; then compound 1.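

In this assay, nitro in place of hydrogen on an aromatic carbon, para to a large group, gives a 2.8-fold higher number from compound 2 to compound 3 (0.45 log units; beyond the scatter), a modest loss of inhibition. This shows that the position is not indifferent to what sits on it, since turning phenyl into 4-nitrophenyl weakens the result. No measurement at hand explains this shift. On these data alone, whether any group here would cost inhibition, or nitro in particular, remains open. An amine or a methoxy group at the same position could help separate those two readings.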